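Adding Benzyloxy to Compound 2

The source may report more compounds than this note shows. Statements on the series, on what has been measured and on what is new or still open speak of the compounds shown alone.

- Compound 1 `Cc1ccccc1C1CC(c2ccc(OCc3ccccc3)cc2)=NN1c1ccc(S(N)(=O)=O)cc1`: >= 100000 nM (a limit)
- Compound 2 `Cc1cccc(C2CC(c3ccccc3)=NN2c2ccc(S(N)(=O)=O)cc2)c1`: 37000 nM

Within the data shown here, in an ADME assay on MT4 cells (Homo sapiens) for cytotoxicity, read by MTT assay, with a stated time of 96 h (a higher number here means that more compound is tolerated, a lower number that less compound is tolerated), compound 2 gives 37000 nM, the only exact number so far. Compound 1 reads >= 100000 nM, which is a limit of the assay and not a number.

Compound 3 `Cc1cccc(C2CC(c3ccc(OCc4ccccc4)cc3)=NN2c2ccc(S(N)(=O)=O)cc2)c1` differs from compound 2 by benzyloxy in place of hydrogen on an aromatic carbon, para to a large group. Among the measured compounds shown here, no measured pair isolates this change. Compound 1, which also carries benzyloxy, points upward with its >= 100000 nM, so a moderate rise in tolerated concentration is expected, perhaps reaching the limit. The expected change is a 2.0-fold higher number from compound 2 to compound 3 (0.31 log units; beyond the scatter). Compound 3 is estimated at 75000 nM, with an expected range of 30000 nM to 100000 nM.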

Compound 3, half-maximal cytotoxic concentration: 44000 nM
Compound 3: middle estimate off by 1.7-fold (0.23 log units), on the high side; low and high end bracket the measured number.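

In this assay benzyloxy in place of hydrogen on an aromatic carbon, para to a large group, gives a 1.2-fold higher number from compound 2 to compound 3 (0.08 log units; within the scatter) and so adds no readable change at this position. With benzyloxy kept, 3-methylphenyl in place of 2-methylphenyl on a saturated ring carbon gives an at least 2.2-fold lower number from compound 1 to compound 3 (0.35 log units; beyond the scatter) and shows that the reading of compound 1 does not follow from benzyloxy alone. Compound 1 reads >= 100000 nM as a limit and not a number: the limit of >= 100000 nM in this assay, at which 1 of the 3 values shown sits.

Open, from the compounds shown here alone, is how far the step from 2-methylphenyl to 3-methylphenyl reaches, since its size rests on that limit. Also open, going by these compounds, is whether an amine or a carboxylic acid on that aromatic carbon would shift the value beyond the scatter.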